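This account rests on a few compounds, and the source may have more. Where it says the series, first, only, none or still open, it means among the compounds named here.

Going by the values given here, in a functional assay on SGC-7901 cells (Homo sapiens) for antiproliferative activity, read by sulforhodamine B assay, with a stated time of 72 h (a lower number here means a stronger inhibitor, a higher number a weaker inhibitor), compound 1 (`FC(F)(F)c1ccccc1NC(=S)N/N=C/c1ccc2ccccc2n1`) gives 20700 nM, the only true number so far. Compound 2 (`Fc1ccccc1NC(=S)N/N=C/c1ccc2ccccc2n1`) reads > 100000 nM and this is a limit of the assay. Compound 3 (`Cc1ccccc1NC(=S)N/N=C/c1ccc2ccccc2n1`) reads > 100000 nM and this too is a limit, so compound 3 has no number and is one of the entries at the limit of > 100000 nM in this assay, at which 2 of the 3 values shown sit.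

Compound 4 (`S=C(N/N=C/c1ccc2ccccc2n1)Nc1ccccc1Br`) carries bromo in place of methyl on an aromatic carbon, ortho to a large group (bromo in place of methyl on an aromatic carbon).

Among the compounds with values here, two measured steps bear on this: fluoro in place of trifluoromethyl gives an at least 4.8-fold higher number from compound 1 to compound 2 (0.68 log units; beyond the scatter) and methyl in place of trifluoromethyl gives an at least 4.8-fold higher number from compound 1 to compound 3 (0.68 log units; beyond the scatter), both beyond the scatter. There is also a step that the two limits leave unreadable from compound 2 to compound 3, which adds nothing. Bromo itself is untested in this series. Going by compound 1 at 20700 nM, a modest move to a lower number in this assay is expected. A reading at the limit remains possible. The expected step is an at least 2.2-fold lower number from compound 3 to compound 4 (0.34 log units; beyond the scatter). For compound 4 the estimated value is 45000 nM, with an expected range from 12000 nM to 120000 nM.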

Compound 4, half-maximal inhibitory concentration: > 100000 nM
Compound 4 was reported as a limit (the forecaster's own chance of this, stated with the estimate: 45%); middle value at least 2.2-fold (0.34 log units) from the limit.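

Compound 4 gives only a limit of the assay in this assay, so bromo on this aromatic carbon joins fluoro and methyl rather than trifluoromethyl. Going by these compounds alone, the one readable step is an at least 4.8-fold higher number from compound 1 to compound 4 (0.68 log units; beyond the scatter), which makes bromo the third replacement of trifluoromethyl at this position to leave a true number out of reach. The steps among compound 2, compound 3 and compound 4 cannot be read, and compound 1 remains the only one of the four with a true number, the rest sharing one reading: the limit of > 100000 nM in this assay, at which 3 of the 4 values shown sit.

On these data alone, what a nitrile or an amine on this aromatic carbon would read remains open. So does whether trifluoromethyl elsewhere on the six-membered aromatic ring would keep a reading short of the limit.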